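Moving the Thiophene Link: Little Change Expected

This account rests on a few compounds, and the source may have more. Where it says the series, first, only, none or still open, it means among the compounds named here.

Compound 1 `CCNC(=O)C1=C(C)NC(=O)NC1c1ccsc1`: 3%
Compound 2 `CC1=C(C(=O)SC(C)C)C(c2cccs2)NC(=O)N1`: 1%

In an assay on membranes from CHO cells for displacement of a labelled ligand from adenosine receptor A1 (Homo sapiens), read by scintillation counting, with a stated time of 60 min, tested at 1 uM (on this read-out lower numbers stand for less inhibition and higher numbers for more inhibition at the one concentration tested (going by the name of the read-out)), compound 2 gives 1%. Among the compounds with values here, the only other measured compound, compound 1, gives 3%, a gap that lies within the usual scatter, so the two cannot be told apart. Compound 3 `CC1=C(C(=O)SC(C)C)C(c2ccsc2)NC(=O)N1` differs from compound 2 by one change: thiophen-3-yl in place of thiophen-2-yl on a saturated ring carbon. Within the data shown here, no step between measured compounds is available, so the size must be judged from the two values alone. Both sit very low, and compound 1, which also carries thiophen-3-yl, gives 3%. Compound 3 is therefore expected to stay low, estimated at 2% (range 0% to 12%), a step of a number 1 percentage points higher from compound 2 to compound 3 (within the scatter) not beyond the scatter.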

Compound 3, a percentage reported as inhibition, at one concentration (the size of the read-out at that concentration, not a potency): 24%
Estimate against measurement, compound 3: 22 percentage points below; the measured number lies above the stated range.
By their numbers in this assay, from the lowest: compounds 2 and 1 (each within the scatter of the next); then compound 3.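

Where the thiophene is attached matters at this saturated ring carbon: thiophen-3-yl in place of thiophen-2-yl gives a number 23 percentage points higher from compound 2 to compound 3 (beyond the scatter) in this assay even though the two groups hold the same atoms. Thiophen-3-yl is not enough alone, as isopropylsulfanyl in place of ethylamino on the carbonyl carbon gives a number 21 percentage points higher from compound 1 to compound 3 (beyond the scatter) with that group kept in place. Nothing measured here explains either step.

The compounds shown leave open whether a phenyl ring at the saturated ring carbon would match thiophen-3-yl. They also leave open how a longer chain on the sulfur would fare.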